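Moving the Chlorine Around the Ring: What Compound 4 Might Give

The source may hold more compounds than are shown below. What is called first, only, known or untested is meant among the compounds shown, and "the series" means these compounds.

Of the compounds shown here, three sharing one core have been measured in a functional assay on NUGC-3 cells (Homo sapiens) for cytotoxicity, read by sulforhodamine B assay, with a stated time of 72 h; on this read-out higher numbers stand for weaker inhibition of growth and lower numbers for stronger inhibition of growth. Compound 1 `O=C(Nc1ccccc1C(F)(F)F)C1CCc2ccccc2N1C(=O)c1cccc(Cl)c1` gives 754 nM. Compound 2 `CCCCCCCCC(=O)N1c2ccccc2CCC1C(=O)Nc1ccccc1O` gives 31100 nM, and compound 3 `O=C(Nc1ccccc1O)C1CCc2ccccc2N1C(=O)c1ccccc1Cl` gives 36800 nM. Compound 3 thus stands with the highest number of the three, close to compound 2 and far from compound 1, whose number is lower by a margin well beyond the scatter.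

The next compound, compound 4 `O=C(Nc1ccccc1O)C1CCc2ccccc2N1C(=O)c1cccc(Cl)c1`, differs from compound 3 in one place: 3-chlorophenyl in place of 2-chlorophenyl on a carbonyl carbon. Among the measured compounds shown here, only one measured step changes the group on that same carbonyl carbon, namely a 1.2-fold higher number from compound 2 to compound 3 (0.07 log units; within the scatter), which shows that swapping octyl for 2-chlorophenyl there left the growth inhibition essentially unchanged. For the measured compounds named here, no measured step moves the chlorine from one position of the phenyl ring to another. Compound 1 does carry the 3-chlorophenyl group and has the lowest number of the set, but it also differs from compound 4 elsewhere, so its value cannot be read as the effect of the chlorine position alone.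

Weighing a neutral step against a hint from compound 1, a modest improvement is expected, a 2.5-fold lower number from compound 3 to compound 4 (0.39 log units; beyond the scatter). Compound 4 is therefore estimated to give 15000 nM, within a range from 3000 nM to 60000 nM.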

Compound 4, concentration for 50% growth inhibition: 11000 nM
Compound 4: middle estimate off by 1.4-fold (0.13 log units), on the high side; low and high end bracket the measured number.
By their numbers in this assay, from the lowest: compound 1; then compound 4; then compounds 2 and 3 (each within the scatter of the next).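

In this assay, the carbonyl carbon on the amide-type ring nitrogen turns out to respond to where the chlorine sits: 3-chlorophenyl in place of 2-chlorophenyl gives a 3.3-fold lower number from compound 3 to compound 4 (0.52 log units; beyond the scatter), and 3-chlorophenyl in place of octyl gives a 2.8-fold lower number from compound 2 to compound 4 (0.45 log units; beyond the scatter), both modest but beyond the scatter, whereas the earlier swap of octyl for 2-chlorophenyl stayed within it. With 3-chlorophenyl now held the same, the comparison with compound 1 also isolates the other end of the molecule: hydroxy in place of trifluoromethyl on an aromatic carbon gives a 15-fold higher number from compound 1 to compound 4 (1.16 log units; beyond the scatter), a large step that shows the group on that aromatic carbon outweighing the chlorine's move in this small set. Nothing available explains either change in terms of what the groups do in the cells.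

The compounds shown leave open whether another group on the same carbonyl carbon, such as 3-fluorophenyl or 3-methoxyphenyl, would go further than 3-chlorophenyl. They also leave open whether the step from 2-chlorophenyl to 3-chlorophenyl keeps its size when trifluoromethyl stands in place of hydroxy, or when an amine or a carboxylic acid does.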